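Removing the fluoro group from compound 3

The compounds below may be only part of what the source reports. "The series", "measured", "known", "first", "only" and "open" are said of these compounds alone.

In a functional assay on A549 cells (Homo sapiens) for cytotoxicity, read by WST assay, with a stated time of 24 h (a lower number here means a stronger inhibitor, a higher number a weaker inhibitor), compound 3 (`COc1ccc(Cn2cc(/C=C(\C#N)C(=O)c3c[nH]c4cc(F)ccc34)c3ccccc32)cc1`) gives > 50000 nM, which is a limit of the assay and not a true number. Compound 1 (`N#C/C(=C\c1cn(Cc2ccc(Cl)cc2)c2ccccc12)C(=O)c1c[nH]c2ccccc12`) gives > 50000 nM, also a limit. Compound 2 (`COc1ccc(Cn2cc(/C=C(\C#N)C(=O)c3c[nH]c4cc(OC)ccc34)c3ccccc32)cc1`) gives a true number, 37400 nM. The results so far therefore cluster at one mark: the limit of > 50000 nM in this assay, at which 2 of the 3 values shown sit.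

Compound 4 (`COc1ccc(Cn2cc(/C=C(\C#N)C(=O)c3c[nH]c4ccccc34)c3ccccc32)cc1`) has hydrogen in place of fluoro on an aromatic carbon, turning 6-fluoro-1H-indol-3-yl into 1H-indol-3-yl: hydrogen in place of fluoro on an aromatic carbon. Going by the values given here, only one measured step touches this group, with fluoro in place of methoxy on an aromatic carbon, and it shows an at least 1.3-fold higher number from compound 2 to compound 3 (0.12 log units; that floor lies within the scatter). Since that step does not clearly exceed the scatter, it gives no reason to expect a real shift in this assay in either direction. The expected change is no more than scatter, with an estimated a number no higher from compound 3 to compound 4 (the limit leaves the size open). For compound 4 the estimate is 50000 nM, with an expected range of 22000 nM to 110000 nM.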

Compound 4, half-maximal inhibitory concentration: > 50000 nM
Compound 4: no number, only a limit (the forecaster's own chance of this, stated with the estimate: 60%); the middle value lies on the limit itself.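

In this assay, the plain 1H-indol-3-yl of compound 4 ends at the same limit of the assay as the 6-fluoro-1H-indol-3-yl of compound 3, so neither hydrogen nor fluoro at this place yields a true number. Hydrogen in place of methoxy gives an at least 1.3-fold higher number from compound 2 to compound 4 (0.12 log units; that floor lies within the scatter), so the one true number in the set is not clearly set apart by this change. The steps from compound 3 and from compound 1 to compound 4 have limits at both ends and cannot be read, and the results now gather at one mark: the limit of > 50000 nM in this assay, at which 3 of the 4 values shown sit.

From the compounds shown here alone, whether another group at this place, such as an amine or a carboxylic acid, would bring the shared core clearly inside the range of the assay stays open. Also open, going by these compounds, is how far past the limit compound 3 and compound 4 lie, and whether they differ at all.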